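The source may report more compounds than this note shows. Statements on the series, on what has been measured and on what is new or still open speak of the compounds shown alone.

In a functional assay on MCF7 cells (Homo sapiens) for cytotoxicity, read by MTT assay, with a stated time of 6 days (a higher number here means that more compound is needed for the effect, a lower number that less compound is needed), three compounds have been measured so far, and each of them stopped at the top of the tested range. Compound 1 `COC(=O)c1c(-c2cc(OC)cc(OC)c2)oc2ccccc2c1=O` carries a methoxycarbonyl group on the shared core. In this assay compound 1 gives > 25 ug/mL, which is a limit of the assay and not a number. Compound 2 `COc1cc(OC)cc(-c2oc3ccccc3c(=O)c2C(=O)O)c1` differs from compound 1 only by methyl in place of hydrogen on an oxygen next to a carbonyl group. In this assay compound 2 gives > 25 ug/mL, again a limit of the assay. The step that the two limits leave unreadable from compound 2 to compound 1 therefore has no readable size. Compound 3 `COc1cc(-c2cc(=O)c3cc(O)ccc3o2)cc(OC)c1OC` rests on a different core from compound 2, and the difference between the two cores is not broken down here. In this assay compound 3 gives > 25 ug/mL, also a limit of the assay. Compound 4 `COc1ccc2oc(-c3cc(OC)c(OC)c(OC)c3)cc(=O)c2c1` is not yet measured; it differs from compound 3 by methyl in place of hydrogen on an oxygen on an aromatic ring. This is the same kind of change as that from compound 2 to compound 1, but not the same: there the place was on an oxygen next to a carbonyl group whose other neighbours are carbonyl carbon, here it is on an oxygen on an aromatic ring whose other neighbours are aromatic carbon. What the earlier step shows is summed up by the limit of > 25 ug/mL in this assay, at which 3 of the 3 values shown sit. The expected step that the limit leaves unreadable from compound 3 to compound 4 is accordingly small. Compound 4 is estimated at 40 ug/mL, most likely reported as the same limit.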

Compound 4, concentration for half-maximal effect: > 25 ug/mL
Compound 4: a limit, no number; the forecaster's own chance of this, stated with the estimate: 85%; the middle value does not contradict the limit.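

Among these compounds, compound 3 and compound 4 both stop at a limit of the assay and not at a number, so the change from hydroxy to methoxy between them has no readable size, and this result gives no new step. The compounds shown leave open how much of any of them would be needed for the effect, and whether any single change alters that amount: the limit of > 25 ug/mL in this assay, at which 4 of the 4 values shown sit.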